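Ester Chain Length and Cytotoxicity in a Quinazoline Series

The source may hold more compounds than are shown below. What is called first, only, known or untested is meant among the compounds shown, and "the series" means these compounds.

Three members of a series of ester-linked quinazoline amides were examined in a functional assay on A549 cells (Homo sapiens) for cytotoxicity, read by MTT assay, with a stated time of 24 h, tested at 40 uM; a lower number here means a stronger effect, a higher number a weaker effect of the compound at the concentration tested. Compound 1 `CCCCCCCCCOC(=O)CCC(=O)N1CCN(CCCOc2cc3c(Nc4ccc(F)c(Cl)c4)ncnc3cc2OC)CC1` gave 17.9% in this assay. Compound 2 `CCCCCCCCCCOC(=O)CCC(=O)N1CCN(CCCOc2cc3c(Nc4ccc(F)c(Cl)c4)ncnc3cc2OC)CC1`, which carries methyl in place of hydrogen on a saturated chain carbon, nine bonds along the chain from an oxygen next to a carbonyl group, gave 15.5%, and the step of a number 2.4 percentage points lower from compound 1 to compound 2 (within the scatter) lies within the scatter of the measurement. Compound 3 `CCCCCCCCCCCCCCCCOC(=O)CCC(=O)N1CCN(CCCOc2cc3c(Nc4ccc(F)c(Cl)c4)ncnc3cc2OC)CC1` differs from compound 1 by heptyl in place of hydrogen on a saturated chain carbon, nine bonds along the chain from an oxygen next to a carbonyl group. In this assay compound 3 gave 82.6%, the highest of the three numbers; the steps of a number 64.7 percentage points higher from compound 1 to compound 3 (beyond the scatter) and a number 67.1 percentage points higher from compound 2 to compound 3 (beyond the scatter) are both beyond the scatter and large, so among these three compound 3 shows the weakest effect.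

Compound 4 `CCCCCCCCCCCCCCCCCOC(=O)CCC(=O)N1CCN(CCCOc2cc3c(Nc4ccc(F)c(Cl)c4)ncnc3cc2OC)CC1` has not yet been measured. It differs from compound 3 by methyl in place of hydrogen on a saturated chain carbon, ten or more bonds along the chain from an oxygen next to a carbonyl group. This is the same kind of change as that from compound 1 to compound 2, which was measured, although the place along the chain differs. The earlier step of this kind, a number 2.4 percentage points lower from compound 1 to compound 2 (within the scatter), stayed within the scatter. Because compound 3 already stands at 82.6%, the step from compound 3 to compound 4 is expected to be small, a number 2.4 percentage points higher from compound 3 to compound 4 (within the scatter), with little room upward. Compound 4 is therefore estimated at 85% in this assay, with a likely range from 68% to 98%.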

Compound 4, a percentage reported as activity, at one concentration (the size of the read-out at that concentration, not a potency): 85.2%
Beside the measured number, compound 4's estimate is 0.2 percentage points below it; low and high end bracket the measured number.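

Adding a methyl to the ester chain changed little in this assay at either chain length, and the step of a number 2.6 percentage points higher from compound 3 to compound 4 (within the scatter) matches the earlier one: the same change on two cores in this assay, a number 2.4 percentage points lower (within the scatter) from compound 1 to compound 2 and a number 2.6 percentage points higher (within the scatter) from compound 3 to compound 4, 5 percentage points apart, within the scatter of two such steps The larger lengthening also kept its size from one starting chain to the other, with the step of a number 69.7 percentage points higher from compound 2 to compound 4 (beyond the scatter) standing close to its counterpart: the same change on two cores in this assay, a number 64.7 percentage points higher (beyond the scatter) from compound 1 to compound 3 and a number 69.7 percentage points higher (beyond the scatter) from compound 2 to compound 4, 5 percentage points apart, within the scatter of two such steps The step of a number 67.3 percentage points higher from compound 1 to compound 4 (beyond the scatter) is large as well, but these pairs show only that each change carried over among these four compounds, which differ solely in the ester chain; they do not show where along the chain lengths from compound 2 to compound 3 the large difference arises, nor whether the same steps would hold on a different core.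

The compounds shown leave open how chains of intermediate length, lying between those of compound 2 and compound 3, or chains shorter than that of compound 1, would behave in this assay. They also leave open whether a branched chain, or a chain ending in an amine or a carboxylic acid, would follow the same course.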